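Trimming a Propyl Chain on Two Related Cores

The source may hold more compounds than are shown below. What is called first, only, known or untested is meant among the compounds shown, and "the series" means these compounds.

Three compounds were tested in a functional assay on the whole organism with Rattus norvegicus as the target, at a dose of 100 mg/kg (a higher number here means more inhibition at the dose given (going by the name of the read-out), a lower number less inhibition), and a fourth awaits its number. Compound 2 `CCC/N=C(/NC#N)NCCCn1nc(-c2ccccc2)ccc1=O` gives 52.9% in this assay. Compound 1 `C/N=C(/NC#N)NCCCn1nc(-c2ccccc2)ccc1=O` carries hydrogen in place of ethyl on a saturated chain carbon bound to a double-bonded nitrogen and gives 40.5%, so the step of a number 12.4 percentage points lower from compound 2 to compound 1 (beyond the scatter). Compound 3 `CCC/N=C(/NC#N)NCCCn1nc(C)ccc1=O` keeps the propyl chain of compound 2 but differs in the core by methyl in place of phenyl on an aromatic carbon, and in this assay compound 3 gives 17.5%, the lowest of the three numbers, with the step of a number 35.4 percentage points lower from compound 2 to compound 3 (beyond the scatter).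

Compound 4 `C/N=C(/NC#N)NCCCn1nc(C)ccc1=O` has not yet been measured. Among the compounds with values here, it differs from compound 3 by hydrogen in place of ethyl on a saturated chain carbon bound to a double-bonded nitrogen, which is the same change, at the same kind of place, as the one that turns compound 2 into compound 1. That earlier change was seen once, on the phenyl-bearing core; here it is applied to the methyl-bearing core of compound 3, so the comparison rests on a single precedent.

The step is expected to be a number 10.5 percentage points lower from compound 3 to compound 4 (beyond the scatter), because a number 12.4 percentage points lower from compound 2 to compound 1 (beyond the scatter) was modest and the starting number of compound 3 is already low, leaving little room to fall. Compound 4 is therefore expected to give about 7% in this assay. The estimated range for compound 4 runs from 0% to 20%.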

Compound 4, a percentage reported as inhibition, in the whole organism at one dose (the size of the read-out at that dose, not a potency): 6.8%
Compound 4: the middle estimate sits 0.2 percentage points above what was measured; the range from low to high includes it.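

In this assay, trimming the propyl chain to methyl on the methyl-bearing core gives a step of a number 10.7 percentage points lower from compound 3 to compound 4 (beyond the scatter), and this closely matches the same trim on the phenyl-bearing core: the same change on two cores in this assay, a number 12.4 percentage points lower (beyond the scatter) from compound 2 to compound 1 and a number 10.7 percentage points lower (beyond the scatter) from compound 3 to compound 4, 1.7 percentage points apart, within the scatter of two such steps. The change from phenyl to methyl on an aromatic carbon also carries over, as the compounds with the shorter chain show a step of a number 33.7 percentage points lower from compound 1 to compound 4 (beyond the scatter), which can be set beside the step seen with the propyl chain: the same change on two cores in this assay, a number 35.4 percentage points lower (beyond the scatter) from compound 2 to compound 3 and a number 33.7 percentage points lower (beyond the scatter) from compound 1 to compound 4, 1.7 percentage points apart, within the scatter of two such steps. Across these four compounds, each change therefore lowers the number by much the same amount whichever form the other part takes, but this rests on only two cores and two chain lengths, at a single dose in one whole-animal test, so it does not show that the trim would transfer to other cores or explain why the numbers fall.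

The compounds shown leave open how a longer chain such as hexyl, or a branched one such as isopropyl, would behave in place of propyl. They also leave open what a benzyl group or an amine would do in place of phenyl or methyl on the aromatic carbon.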